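This account rests on a few compounds, and the source may have more. Where it says the series, first, only, none or still open, it means among the compounds named here.

Compound 1 `Cc1nc(CN2CCN(c3cccc4[nH]c(-c5ccc(C(C)(C)C)cc5)nc34)CC2)c[nH]1` gives 28 nM in an assay on isolated protein for displacement of a labelled ligand from Gonadotropin-releasing hormone receptor (Rattus norvegicus); a lower number here means a stronger inhibitor, a higher number a weaker inhibitor.
Compound 2 `CCc1cc(CN2CCN(c3cccc4[nH]c(-c5ccc(C(C)(C)C)cc5)nc34)CC2)n(C)n1` gives 250 nM in this assay.
Compound 3 `CCCCn1cnc(CN2CCN(c3cccc4[nH]c(-c5ccc(C(C)(C)C)cc5)nc34)CC2)c1C` gives 49 nM in this assay.

Compound 3 stands second highest of the three numbers; its nearest neighbour is compound 1, within the scatter, and its furthest is compound 2, beyond it. Compound 4 `CCn1cc(CN2CCN(c3cccc4[nH]c(-c5ccc(C(C)(C)C)cc5)nc34)CC2)nc1C` differs from compound 3 only at the heterocycle: 1-ethyl-2-methyl-1H-imidazol-4-yl in place of 1-butyl-5-methyl-1H-imidazol-4-yl on a saturated chain carbon bound to an amine nitrogen in a ring. Among the measured compounds shown here, no measured step makes exactly this change. The step that bears most on it is a 1.8-fold higher number from compound 1 to compound 3 (0.24 log units; within the scatter), which shows that adding alkyl to the imidazole nitrogen and methyl to its ring does not move the number beyond the scatter. The large steps of an 8.9-fold higher number from compound 1 to compound 2 (0.95 log units; beyond the scatter) and a 5.1-fold lower number from compound 2 to compound 3 (0.71 log units; beyond the scatter) involve the pyrazole of compound 2 and so do not bear on compound 4, which keeps an imidazole. Compound 4 is therefore expected to sit within the scatter of compound 3, with a 1.4-fold lower number from compound 3 to compound 4 (0.15 log units; within the scatter) estimated as no step beyond the scatter. For compound 4 the estimate in this assay is 35 nM, with a range of 12 nM to 110 nM.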

Compound 4, half-maximal inhibitory concentration: 51 nM
Beside the measured number, compound 4's estimate is 1.5-fold (0.16 log units) below it, and the stated range covers the measured number.
By their numbers in this assay, from the lowest: compounds 1, 3 and 4 (each within the scatter of the next); then compound 2.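

In this assay, a 1.8-fold higher number from compound 1 to compound 4 (0.26 log units; within the scatter) isolates ethyl in place of hydrogen on an aromatic nitrogen and leaves the number within the scatter, whereas the earlier step to compound 3 changed two features of the imidazole at once. Alkyl chain and ring methyl can also differ together without a step beyond the scatter, as a 1.0-fold higher number from compound 3 to compound 4 (0.02 log units; within the scatter) shows for 1-ethyl-2-methyl-1H-imidazol-4-yl in place of 1-butyl-5-methyl-1H-imidazol-4-yl, while a 4.9-fold lower number from compound 2 to compound 4 (0.69 log units; beyond the scatter) puts compound 2 beyond the scatter of a third imidazole. Nothing available here accounts for these steps.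

Compound 2 differs from the imidazoles in both ring and substituents, so the shown compounds do not separate these two changes. On these data alone, the response to an amine, a carboxylic acid or a phenyl group on the imidazole nitrogen also remains open.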